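From Butoxy to Dimethylamino in a Small Series

The compounds below may be only part of what the source reports. "The series", "measured", "known", "first", "only" and "open" are said of these compounds alone.

Measured in a functional assay (Homo sapiens) for inhibition; on this read-out higher numbers stand for weaker inhibition and lower numbers for stronger inhibition:
compound 1 `COc1cc(O)cc(C)c1/C=C/C(=O)c1ccc(O)cc1`: 53000 nM
compound 2 `O=C(/C=C/c1ccc([N+](=O)[O-])cc1)c1ccc([N+](=O)[O-])cc1`: 51000 nM
compound 3 `CCCCOc1ccccc1C(=O)/C=C/c1cc(OC)cc(OC)c1`: 13000 nM

Within the data shown here, only three numbers are available, so this is a thin base for any prediction. Among them, compound 3 at 13000 nM has the lowest number and therefore the strongest inhibition, and its gap to each of the other two lies beyond the usual scatter. Compound 1 and compound 2 lie within the scatter of each other.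

The next compound is compound 4 `COc1cc(/C=C/C(=O)c2ccccc2N(C)C)cc(OC)c1`. It has dimethylamino in place of butoxy on an aromatic carbon of a six-membered aromatic ring of carbon only, ortho to a large group (dimethylamino in place of butoxy on an aromatic carbon). Among the measured compounds shown here, no two measured compounds differ in just one place, so the data offer no direct guide to this change. A modest rise in the number, meaning weaker inhibition, is expected in this assay, though a step within the scatter would be no surprise. The reasoning is cautious: compound 3 is the lowest of the three at 13000 nM, so a new compound is more likely to land above it than below it. The estimated step is a 1.7-fold higher number from compound 3 to compound 4 (0.23 log units; within the scatter). For compound 4 the estimated value is 22000 nM, with an expected range from 7000 nM to 60000 nM.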

Compound 4, half-maximal inhibitory concentration: 5700 nM
For compound 4 the middle estimate is 3.9-fold (0.59 log units) above the measured one, outside the stated range (below it).
By their numbers in this assay, from the lowest: compound 4; then compound 3; then compounds 2 and 1 (each within the scatter of the next).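

In this assay, putting dimethylamino in place of butoxy on an aromatic carbon of a six-membered aromatic ring of carbon only, ortho to a large group, gives a 2.3-fold lower number from compound 3 to compound 4 (0.36 log units; beyond the scatter), a modest step that lies beyond the usual scatter. Among these compounds, this is the first pair that differs in just one place, so it gives the first direct reading of a change, and it shows that this position does not depend on butoxy: a group of 3 heavy atoms replaces one of 5, with the same count of hydrogen-bond acceptors, and inhibition becomes stronger rather than weaker. Nothing measured here explains why the step goes in this direction.

A single pair cannot separate the effect of swapping oxygen for nitrogen at the point of attachment from the effect of losing the longer chain, so groups such as diethylamino, ethoxy or a plain amine would be needed to tell the two apart. From the compounds shown here alone, it also remains open whether the same swap would give a similar step on the core of compound 1 or compound 2.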